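Dimethoxyphenyl Swap Tested on Two Related Cores

The compounds below may be only part of what the source reports. "The series", "measured", "known", "first", "only" and "open" are said of these compounds alone.

Compound 1 `CC(=O)Oc1c(Br)cc(Br)cc1/C=C1\N=C(c2ccccc2)n2c(=S)nc(C)n2C1=O` was assessed in a functional assay on MCF7 cells (Homo sapiens) for antiproliferative activity, read by MTT assay, with a stated time of 48 h (on this read-out higher numbers stand for weaker inhibition and lower numbers for stronger inhibition), and gave only a limit, > 100000 nM, which is the limit of > 100000 nM in this assay, at which 1 of the 3 values shown sits. Compound 2 `COc1ccc(C2=N/C(=C\c3cc(Br)cc(Br)c3OC(C)=O)C(=O)n3c(C)nc(=S)n32)cc1OC` gave 6840 nM in this assay. The two differ by 3,4-dimethoxyphenyl in place of phenyl on a carbon with a double bond to nitrogen, and this change gave an at least 14-fold lower number from compound 1 to compound 2 (1.16 log units; beyond the scatter). Compound 3 `CC(=O)Oc1c(Br)cc(Br)cc1/C=C1\N=C(c2ccccc2)N(c2ccccc2)NC1=O`, built on a different core, gave 19400 nM in this assay, the highest number among the measured values; how its core differs from the core of compound 1 is not broken down here.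

Compound 4 `COc1ccc(C2=N/C(=C\c3cc(Br)cc(Br)c3OC(C)=O)C(=O)NN2c2ccccc2)cc1OC` is not yet measured. It differs from compound 3 by 3,4-dimethoxyphenyl in place of phenyl on a carbon with a double bond to nitrogen, the same kind of change as before, though here the place is next to the ring atom that bears a phenyl group and is not part of a fused or bridged system of two rings. Because the earlier change gave an at least 14-fold lower number from compound 1 to compound 2 (1.16 log units; beyond the scatter), compound 4 is expected to show a 6.5-fold lower number from compound 3 to compound 4 (0.81 log units; beyond the scatter), somewhat smaller since the surroundings differ. Compound 4 is estimated at 3000 nM, within 800 nM to 12000 nM.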

Compound 4, half-maximal inhibitory concentration: 5390 nM
Beside the measured number, compound 4's estimate is 1.8-fold (0.25 log units) below it; measured number inside the range.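

In this assay, 3,4-dimethoxyphenyl in place of phenyl lowered the number on the second core too, with a 3.6-fold lower number from compound 3 to compound 4 (0.56 log units; beyond the scatter), so the direction of the change carried over, but its size did not: the same change on two cores in this assay, an at least 14-fold lower number (1.16 log units; beyond the scatter) from compound 1 to compound 2 and a 3.6-fold lower number (0.56 log units; beyond the scatter) from compound 3 to compound 4, at least 4.0-fold (0.60 log units) apart, beyond the scatter of two such steps

Compound 1 stands at a limit of the assay and not at a number: the limit of > 100000 nM in this assay, at which 1 of the 4 values shown sits.

The step from that compound therefore gives only a minimum size, and these two pairs of compounds neither say what in the cores sets the size of the step nor predict how the change would behave on any further core.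

The compounds shown leave open whether both methoxy groups are needed, since a single methoxy group, a hydroxyl group or a dimethylamino group in place of phenyl does not appear among them. Among these compounds, they also leave open how the acetyl ester contributes on either core, as no compound here carries a free hydroxyl group or a longer ester chain there.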